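Shifting the aryl group on the shared core

This account rests on a few compounds, and the source may have more. Where it says the series, first, only, none or still open, it means among the compounds named here.

Measured in a functional assay on HepG2 cells (Homo sapiens) for cytotoxicity, read by MTT assay, with a stated time of 72 h; a higher number here means a weaker inhibitor, a lower number a stronger inhibitor:
compound 1 `COc1ccc(-n2ccc(=O)c(C(=O)Nc3ccc(Oc4ccnc5[nH]ccc45)cc3)n2)cc1` gives 50800 nM
compound 2 `O=C(Nc1ccc(Oc2ccnc3[nH]ccc23)cc1)c1nn(-c2ccc(Br)cc2)ccc1=O` gives 4280 nM
compound 3 `O=C(Nc1ccc(Oc2ccnc3[nH]ccc23)cc1)c1nn(-c2ccc(Br)cc2F)ccc1=O` gives 46400 nM

Compound 3 stands second highest of the three numbers in this assay; its nearest neighbour is compound 1, and the two differ only within the scatter, as shown by a 1.1-fold lower number from compound 1 to compound 3 (0.04 log units; within the scatter). Its furthest neighbour is compound 2, separated by an 11-fold higher number from compound 2 to compound 3 (1.04 log units; beyond the scatter), a large step.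

Compound 4 `O=C(Nc1ccc(Oc2ccnc3[nH]ccc23)cc1)c1nn(-c2ccc(Cl)c(C(F)(F)F)c2)ccc1=O` differs from compound 3 in one place: 4-chloro-3-(trifluoromethyl)phenyl in place of 4-bromo-2-fluorophenyl on an aromatic nitrogen. Among the measured compounds shown here, two measured steps bear on this change. The step of a 12-fold lower number from compound 1 to compound 2 (1.07 log units; beyond the scatter) shows that a halogen on the aryl ring can lower the number by a large margin, and an 11-fold higher number from compound 2 to compound 3 (1.04 log units; beyond the scatter) shows that adding fluoro raised it again by a comparable margin. For the measured compounds named here, compound 4 keeps a halogen but drops the fluoro, and adds a trifluoromethyl whose effect has no measured counterpart here. A step toward the level of compound 2 is therefore expected, but with wide uncertainty; compound 4 is estimated at 8000 nM, within 2000 nM to 40000 nM, meaning an expected step of a 5.8-fold lower number from compound 3 to compound 4 (0.76 log units; beyond the scatter).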

Compound 4, half-maximal inhibitory concentration: 1320 nM
Estimate against measurement, compound 4: 6.1-fold (0.78 log units) above, outside the stated range (below it).
By their numbers in this assay, from the lowest: compound 4; then compound 2; then compounds 3 and 1 (each within the scatter of the next).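

In this assay the aryl group on the aromatic nitrogen can take the number past the level set by 4-bromophenyl, with a 3.2-fold lower number from compound 2 to compound 4 (0.51 log units; beyond the scatter) as a modest step. Among the compounds shown here, the larger steps, a 35-fold lower number from compound 3 to compound 4 (1.55 log units; beyond the scatter) and a 38-fold lower number from compound 1 to compound 4 (1.59 log units; beyond the scatter), show that exchanging this aryl group alone can move the number further than any step among the earlier compounds, with all other parts of the molecule unchanged. No measurement shown here explains why 4-chloro-3-(trifluoromethyl)phenyl gives the lowest number of the four.

Going by these compounds, compound 4 brings in chloro and trifluoromethyl together, so the share of each in these steps stays open. Also open, on these data alone, is how this aryl group would behave with an amine or a carboxylic acid in place of the halogen.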